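Adding a Hydroxy Group to a Cyclic Peptide Core

This account rests on a few compounds, and the source may have more. Where it says the series, first, only, none or still open, it means among the compounds named here.

Compound 1 `C[C@@H]1NC(=O)[C@@H](C)NC(=O)[C@@H]2Cc3cccc(c3)Oc3ccc(cc3)C[C@@H](C(=O)N2C)N(C)C(=O)[C@H](C)NC(=O)[C@H](Cc2ccccc2)N(C)C1=O` and compound 2 `C[C@@H]1NC(=O)[C@@H](C)NC(=O)[C@@H]2Cc3ccc(O)c(c3)Oc3ccc(cc3)C[C@@H](C(=O)N2C)N(C)C(=O)[C@H](C)NC(=O)[C@H](Cc2ccccc2)N(C)C1=O` share a core and differ in one place: hydroxy in place of hydrogen on an aromatic carbon. In a functional assay on P388 cells (Mus musculus) for cytotoxicity (on this read-out lower numbers stand for stronger inhibition and higher numbers for weaker inhibition), compound 1 gives 525 nM, while compound 2 gives 42.7 nM, so the change made a 12-fold lower number from compound 1 to compound 2 (1.09 log units; beyond the scatter). Compound 3 `COc1ccc(C[C@H]2C(=O)N[C@@H](C)C(=O)N(C)[C@H]3Cc4ccc(cc4)Oc4cc(ccc4OC)C[C@@H](C(=O)N[C@H](C)C(=O)N[C@@H](C)C(=O)N2C)N(C)C3=O)cc1O` is built on a second core; how it differs from compound 1 is not broken down here. In this assay compound 3 gives 214 nM. Compound 4 `COc1ccc(C[C@H]2C(=O)N[C@@H](C)C(=O)N(C)[C@H]3Cc4ccc(c(O)c4)Oc4cc(ccc4OC)C[C@@H](C(=O)N[C@H](C)C(=O)N[C@@H](C)C(=O)N2C)N(C)C3=O)cc1O` has not yet been measured; it differs from compound 3 in one place: hydroxy in place of hydrogen on an aromatic carbon. Among the compounds with values here, this is the same kind of change as the one from compound 1 to compound 2, though not the same: in compound 2 the new group sits ortho to a fused ring and para to a fused ring, whereas in compound 4 it sits ortho to a fused ring and meta to a fused ring. Since the earlier change produced a 12-fold lower number from compound 1 to compound 2 (1.09 log units; beyond the scatter), a similar drop is expected for compound 4. The placement and the core differ, and the expectation is held with less certainty for that reason. Compound 4 is estimated to give 35 nM in this assay, between 10 nM and 120 nM, a step of a 6.1-fold lower number from compound 3 to compound 4 (0.79 log units; beyond the scatter).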

Compound 4, half-maximal inhibitory concentration: 15100 nM
Beside the measured number, compound 4's estimate is 430-fold (2.63 log units) below it; measured number outside the range, above it.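

Replacing hydrogen with hydroxy on an aromatic carbon gave a 71-fold higher number from compound 3 to compound 4 (1.85 log units; beyond the scatter) in this assay, so this change moved the number in the opposite direction on the core of compound 3, and the two steps clearly disagree: the same change on two cores in this assay, a 12-fold lower number (1.09 log units; beyond the scatter) from compound 1 to compound 2 and a 71-fold higher number (1.85 log units; beyond the scatter) from compound 3 to compound 4, 870-fold (2.94 log units) apart, beyond the scatter of two such steps

This shows that the result of this change on the core of compound 1 cannot simply be carried over to the core of compound 3, since a large improvement on one became a large loss on the other. It does not show why, since the core and the placement of the new hydroxy both differ between the two pairs, with the group ortho to a fused ring and para to a fused ring in compound 2 but ortho to a fused ring and meta to a fused ring in compound 4, and these two differences cannot be separated here.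

The compounds shown leave open whether the reversal follows the core or the placement, as no pair here has the same placement on both cores. They also leave open how an amine or a carboxylic acid on that aromatic carbon would behave on either core.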